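Shifting a methyl group on compound 1

This account rests on a few compounds, and the source may have more. Where it says the series, first, only, none or still open, it means among the compounds named here.

compound 1 `Cc1ccccc1C1CC(c2ccc(OCc3ccccc3)cc2)=NN1c1ccc(S(N)(=O)=O)cc1` gives 20000 nM
compound 2 `NS(=O)(=O)c1ccc(N2N=C(c3ccc(OCc4ccccc4)cc3)CC2c2ccccc2)cc1` gives 80000 nM
compound 3 `Cc1cccc(C2CC(c3ccc(Oc4ccccc4)cc3)=NN2c2ccc(S(N)(=O)=O)cc2)c1` gives 8000 nM

In an ADME assay on BHK-21 cells (Mesocricetus auratus) for cytotoxicity, read by MTT assay, with a stated time of 72 h (on this read-out higher numbers stand for lower toxicity in this test and lower numbers for higher toxicity in this test), compound 1 stands second highest of these three numbers, with compound 3 lower and compound 2 higher. Compound 4 `Cc1ccc(C2CC(c3ccc(OCc4ccccc4)cc3)=NN2c2ccc(S(N)(=O)=O)cc2)cc1` has not yet been measured. It has the same atoms as compound 1, joined differently: 4-methylphenyl in place of 2-methylphenyl on a saturated ring carbon. Within the data shown here, only one measured step bears directly on this change. Removing the methyl altogether gave a 4.0-fold higher number from compound 1 to compound 2 (0.60 log units; beyond the scatter), a modest step beyond the scatter. Compound 4 still carries its methyl, so the full size of that step is not expected here. Compound 3 differs from compound 1 in more than one place and offers no clean comparison. In this assay the expected result is a slight upward drift at most, giving an estimated 1.3-fold higher number from compound 1 to compound 4 (0.10 log units; within the scatter) that stays within the scatter. The estimated value for compound 4 is 25000 nM, with an expected range from 9000 nM to 70000 nM.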

Compound 4, half-maximal cytotoxic concentration: 32000 nM
Compound 4: middle estimate off by 1.3-fold (0.11 log units), on the low side; measured number inside the range.
By their numbers in this assay, from the lowest: compound 3; then compounds 1 and 4 (each within the scatter of the next); then compound 2.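

Moving the methyl from the 2-methylphenyl to the 4-methylphenyl arrangement gives a 1.6-fold higher number from compound 1 to compound 4 (0.20 log units; within the scatter), so in this assay the data do not separate these two placements. Adding a methyl still gives a 2.5-fold lower number from compound 2 to compound 4 (0.40 log units; beyond the scatter), and this step sits beside the earlier 4.0-fold higher number from compound 1 to compound 2 (0.60 log units; beyond the scatter). Among these three compounds, then, the clear difference lies between having a methyl on this phenyl ring and having none, while the two methyl placements cannot be told apart. Nothing available here explains this result.

Going by these compounds, it remains open whether an ethyl, a methoxy or a chlorine on this same phenyl ring would match the methyl compounds or compound 2. A single methyl-free comparison also cannot show whether the same difference would appear with a different group on the shared core.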